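The source may hold more compounds than are shown below. What is called first, only, known or untested is meant among the compounds shown, and "the series" means these compounds.

Measured compounds:
compound 1 `COc1ccc(-c2cc(/C=C/C(=O)c3ccc(N)cc3)[nH]n2)cc1` — 93%
compound 2 `COc1cc(-c2cc(/C=C/C(=O)c3ccc(N)cc3)[nH]n2)cc(OC)c1OC` — 87%

Both compounds were tested in a functional assay on Hs-578T cells (Homo sapiens) for cytotoxicity, read by sulforhodamine B assay, with a stated time of 48 h, tested at 1 uM; a higher number here means a weaker effect of the compound at the concentration tested, a lower number a stronger effect. Compound 1 gives 93%, and compound 2 gives 87%. Read together, both numbers are high, which means that at the concentration used neither compound does much to the cells. Compound 2 has the smaller of the two numbers, but the gap to compound 1 is within the usual scatter of such measurements, so the two compounds cannot be told apart on this evidence.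

Compound 3 `COc1cc(-c2cc(/C=C/C(=O)c3ccc(Cl)c(Cl)c3)[nH]n2)cc(OC)c1OC` shares the core of compound 2 and differs from it in one place: 3,4-dichlorophenyl in place of 4-aminophenyl on a carbonyl carbon. Going by the values given here, no pair of measured compounds shows what this kind of change does, so there is no measured step to lean on. Given that compound 2 and compound 1 both sit near the top of the scale, the expectation for compound 3 is a small step, if any, in this assay, most likely no larger than the scatter, with a slight lean toward a lower number. The expected step is a number 7 percentage points lower from compound 2 to compound 3 (within the scatter). Compound 3 is therefore estimated at 80%, with a range from 55% to 100%.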

Compound 3, a percentage reported as activity, at one concentration (the size of the read-out at that concentration, not a potency): 104%
The estimate for compound 3 lay 24 percentage points below the measured number, and the stated range ends below it.
By their numbers in this assay, from the lowest: compounds 2 and 1 (each within the scatter of the next); then compound 3.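

In this assay, putting 3,4-dichlorophenyl in place of 4-aminophenyl on a carbonyl carbon gives a number 17 percentage points higher from compound 2 to compound 3 (beyond the scatter) and so a weaker effect on the cells at the concentration tested. This shows that the group at this position can shift the read-out by more than repeat measurements would, something compounds 1 and 2 could not show, since their difference lies elsewhere in the molecule. Nothing available accounts for the step, so the swap can only be recorded as a change that brings no gain here.

Only this one replacement at the position is shown, and it starts from a compound that already does little to the cells, so it remains open whether a plain phenyl, a 4-chlorophenyl or a 4-dimethylaminophenyl group would move the number down rather than up. Also open, from the compounds shown here alone, is whether the same replacement on the core of compound 1 would give a step of similar size.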